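A Second Chlorine on the Amide Aryl Ring

The compounds below may be only part of what the source reports. "The series", "measured", "known", "first", "only" and "open" are said of these compounds alone.

Measured compounds:
compound 1, `O=C(Nc1cccc(/C=C/C(=O)c2nc3ccccc3[nH]2)c1)c1cccc(Cl)c1`, 7840 nM
compound 2, `Cc1ccccc1C(=O)Nc1cccc(/C=C/C(=O)c2nc3ccccc3[nH]2)c1`, 5870 nM
compound 3, `COc1cccc(C(=O)Nc2cccc(/C=C/C(=O)c3nc4ccccc4[nH]3)c2)c1`, 17800 nM

All three share one core and differ only in the aryl group attached to the amide carbonyl. In a functional assay on MCF7 cells (Homo sapiens) for antiproliferative activity, read by MTT assay, with a stated time of 48 h (on this read-out higher numbers stand for weaker inhibition and lower numbers for stronger inhibition), compound 1 holds the second highest of the three numbers. Its nearest neighbour is compound 2, reached by a 1.3-fold lower number from compound 1 to compound 2 (0.13 log units; within the scatter), a gap within the scatter, so the two cannot be ranked against each other. The furthest is compound 3, reached by a 2.3-fold higher number from compound 1 to compound 3 (0.36 log units; beyond the scatter), a modest step beyond the scatter; the same direction is seen in a 3.0-fold higher number from compound 2 to compound 3 (0.48 log units; beyond the scatter).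

Compound 4, `O=C(Nc1cccc(/C=C/C(=O)c2nc3ccccc3[nH]2)c1)c1cc(Cl)cc(Cl)c1`, is made from compound 1 by a single change: chloro in place of hydrogen on an aromatic carbon. Among the measured compounds shown here, no measured step adds a group to an otherwise unchanged aryl ring; the steps that exist swap one aryl group for another, and the only one touching the chloro, a 2.3-fold higher number from compound 1 to compound 3 (0.36 log units; beyond the scatter), replaces it rather than adding a second one. The measured steps therefore give no direction for this change, and a step within the scatter is expected. Compound 4 is estimated at 7000 nM, between 3000 nM and 18000 nM, which is expected to be a step of a 1.1-fold lower number from compound 1 to compound 4 (0.05 log units; within the scatter).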

Compound 4, half-maximal inhibitory concentration: > 100000 nM
Compound 4: a limit, no number; the forecaster's own chance of this, stated with the estimate: 5%; at least 14-fold (1.15 log units) between middle value and limit.
By their numbers in this assay, from the lowest: compounds 2 and 1 (each within the scatter of the next); then compound 3. At a limit, above all of these: compound 4.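

For compound 4 the result in this assay is a limit and not a number: the limit of > 100000 nM in this assay, at which 1 of the 4 values shown sits. Among the compounds shown, this is the only change that adds a group to an otherwise unchanged aryl ring, and one extra chloro, meta to the chloro group already there, brings an at least 12-fold higher number from compound 1 to compound 4 (1.10 log units; beyond the scatter), a much larger shift than the largest swap among the earlier compounds, a 3.0-fold higher number from compound 2 to compound 3 (0.48 log units; beyond the scatter). The 3,5-dichlorophenyl group also stands apart from both other aryl groups, with an at least 5.6-fold higher number from compound 3 to compound 4 (0.74 log units; beyond the scatter) and an at least 17-fold higher number from compound 2 to compound 4 (1.23 log units; beyond the scatter), so on this ring a single added heavy atom can separate measurable activity from a result at the limit.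

From the compounds shown here alone, what remains open is whether this sharp change belongs to chloro in particular or to any group at that place on the ring, a question that a fluoro group or an amine there could help settle. The compounds shown also cannot tell whether the same second chloro would have a similar effect with the other aryl groups, such as the 3-methoxyphenyl group of compound 3.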